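The source may report more compounds than this note shows. Statements on the series, on what has been measured and on what is new or still open speak of the compounds shown alone.

Working notes on the series, read in a functional assay on Bel-7402 cells (Homo sapiens) for cytotoxicity, read by MTT assay; a higher number here means a weaker inhibitor, a lower number a stronger inhibitor. Going by the values given here, compound 2 `CCn1cc(C(=O)Nc2ccc(OC)cc2)c(=O)c2cc(F)c(N3CCNC(C)C3)c(F)c21` gives 5400 nM, the only true number so far in this assay. Compound 1 `CCn1cc(C(=O)Nc2ccccc2O)c(=O)c2cc(F)c(N3CCNC(C)C3)c(F)c21` reads > 50000 nM, which is a limit and not a number. Among the compounds with values here, the one measured step, an at least 9.2-fold lower number from compound 1 to compound 2 (0.96 log units; beyond the scatter), swaps 2-hydroxyphenyl for 4-methoxyphenyl on the same amide-type nitrogen, so the group at this place can move the read-out well beyond the scatter. Compound 3 `CCn1cc(C(=O)NCc2ccc(OC)cc2)c(=O)c2cc(F)c(N3CCNC(C)C3)c(F)c21` differs from compound 2 as follows: 4-methoxybenzyl in place of 4-methoxyphenyl on an amide-type nitrogen. That is 4-methoxybenzyl in place of 4-methoxyphenyl on an amide-type nitrogen. Within the data shown here, no measured step covers this exchange, and the step to compound 2 gives no direction for it. A modest move toward a weaker number is expected, possibly not beyond the scatter. The expected step is a 1.5-fold higher number from compound 2 to compound 3 (0.17 log units; within the scatter). For compound 3 the estimated value is 8000 nM, with an expected range of 2500 nM to 30000 nM.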

Compound 3, half-maximal inhibitory concentration: 10300 nM
Compound 3: the middle estimate sits 1.3-fold (0.11 log units) below what was measured, within the range that was stated.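

Exchanging 4-methoxyphenyl for 4-methoxybenzyl on the amide-type nitrogen gives a 1.9-fold higher number from compound 2 to compound 3 (0.28 log units; within the scatter) and so does not separate the two groups in this assay at this place. Compound 1 reads > 50000 nM as a limit and not a number. The exchange of 2-hydroxyphenyl for 4-methoxybenzyl gives an at least 4.8-fold lower number from compound 1 to compound 3 (0.68 log units; beyond the scatter) and so, like 4-methoxyphenyl, 4-methoxybenzyl stands apart from 2-hydroxyphenyl, though the size of this step is only a bound: the limit of > 50000 nM in this assay, at which 1 of the 3 values shown sits.

The compounds shown do not tell whether that gap follows from the hydroxy group of compound 1 or from the methoxy group of compound 2 and compound 3. Going by these compounds, how an unsubstituted phenyl, a longer 2-(4-methoxyphenyl)ethyl chain or a carboxylic acid on the aromatic ring would read at this amide-type nitrogen remains open.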